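The compounds below may be only part of what the source reports. "The series", "measured", "known", "first", "only" and "open" are said of these compounds alone.

Measured compounds:
compound 1 `COc1ccc(-c2cc(/C=C/C(=O)c3ccc(OC)c(OC)c3)[nH]n2)cc1` — 91%
compound 2 `COc1cc(-c2cc(/C=C/C(=O)c3ccc(Cl)c(Cl)c3)[nH]n2)cc(OC)c1OC` — 84%
compound 3 `COc1ccc(-c2cc(/C=C/C(=O)c3cc(OC)c(OC)c(OC)c3)[nH]n2)cc1OC` — 99%

All three values come from a functional assay on A498 cells (Homo sapiens) for cytotoxicity, read by sulforhodamine B assay, with a stated time of 48 h, tested at 0.01 uM; a higher number here means a weaker effect of the compound at the concentration tested, a lower number a stronger effect. Compound 2 gives the lowest of the three numbers, with 84%. Against compound 1, which gives 91%, the gap lies within the scatter, so no order between compound 1 and compound 2 can be read. Against compound 3, which gives 99%, the gap lies beyond the scatter, so compound 2 reads stronger than compound 3 at this concentration.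

Compound 4 `COc1cc(-c2cc(/C=C/C(=O)c3ccc(F)c(F)c3)[nH]n2)cc(OC)c1OC` has not yet been measured. It differs from compound 2 in one place: 3,4-difluorophenyl in place of 3,4-dichlorophenyl on a carbonyl carbon. Within the data shown here, no step between measured compounds carries this kind of exchange, so the size of the step in this assay is not anchored by a measured pair. Given that the largest gap among the measured compounds is only modest, the expectation is for no step beyond the scatter, or at most a small one toward a weaker effect. Compound 4 is expected to give 88% in this assay, with a range from 75% to 100%; the step this estimate means is a number 4 percentage points higher from compound 2 to compound 4 (within the scatter).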

Compound 4, a percentage reported as activity, at one concentration (the size of the read-out at that concentration, not a potency): 100%
For compound 4 the middle estimate is 12 percentage points below the measured one; the measured number falls inside the stated range.
By their numbers in this assay, from the lowest: compounds 2, 1, 3 and 4 (each within the scatter of the next, the first and the last beyond it).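

In this assay, a number 16 percentage points higher from compound 2 to compound 4 (beyond the scatter) gives the series its first one-place comparison, and it shows that the read-out at this position is sensitive to the halogen: 3,4-difluorophenyl on the carbonyl carbon reads weaker than 3,4-dichlorophenyl, by a modest step. The two groups match in heavy-atom count, ring, hydrogen-bond donors and acceptors and charge, so this step goes with the exchange of chlorine for fluorine and not with any of these counted features. No measurement at hand explains the step.

As far as these compounds go, whether 3,4-dibromophenyl or unsubstituted phenyl at the same place would extend this step stays open. So does whether the exchange has the same effect on the core of compound 1 or compound 3, or at other concentrations.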